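A few compounds are considered here, and "the series" means these few. Any claim that something is new, unique, unknown or untested is made for them only; others in the source may bear on it.

Measured so far:
- compound 1, `CCCc1cc(NC)c2cc(NC(=O)/C=C/c3ccc(C(F)(F)F)cc3)ccc2n1`: 1.5 nM
- compound 2, `CCCc1cc(N)c2cc(NC(=O)/C=C/c3ccc(O)cc3)ccc2n1`: 1100 nM
- compound 3, `Nc1cc(-c2ccccc2)nc2ccc(NC(=O)/C=C/c3ccc(C(F)(F)F)cc3)cc12`: 18.5 nM

All three were tested in an assay on isolated protein for displacement of a labelled ligand from melanin-concentrating hormone receptor 1 (Homo sapiens); a lower number here means a stronger inhibitor, a higher number a weaker inhibitor. Compound 2 stands highest of the three numbers, well beyond the scatter from both others: compound 2 gives 1100 nM, while compound 3 gives 18.5 nM and compound 1 gives 1.5 nM, both far lower. Among the compounds with values here, compounds 1 and 3 both carry a trifluoromethyl group where compound 2 carries a hydroxy group; they differ from compound 2 in other places too, so no single step between measured compounds is available.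

Compound 4, `CCCc1cc(N)c2cc(NC(=O)/C=C/c3ccc(CC)cc3)ccc2n1`, has not yet been tested in this assay. It differs from compound 2 in one place: ethyl in place of hydroxy on an aromatic carbon. The change reads 4-hydroxyphenyl to 4-ethylphenyl. Since the two compounds that lack the hydroxy group, compound 1 with 1.5 nM and compound 3 with 18.5 nM, give much lower numbers, a large step downward from compound 2 is expected, a 44-fold lower number from compound 2 to compound 4 (1.64 log units; beyond the scatter). Compound 4 is therefore estimated at 25 nM, within the range 5 nM to 120 nM.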

Compound 4, half-maximal inhibitory concentration: 1.4 nM
Beside the measured number, compound 4's estimate is 18-fold (1.25 log units) above it; the measured number lies below the stated range.
By their numbers in this assay, from the lowest: compounds 4 and 1 (each within the scatter of the next); then compound 3; then compound 2.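

Within the data shown here, this is the first step that changes only one place. In this assay, replacing 4-hydroxyphenyl with 4-ethylphenyl gives a 790-fold lower number from compound 2 to compound 4 (2.90 log units; beyond the scatter) while the rest of the structure stays the same. The substituent on this aromatic ring therefore has a very large influence on the number, and here the hydroxy group with its hydrogen-bond donor and acceptor is replaced by an ethyl group that has neither. Nothing available explains why the change has so large an effect.

The pair cannot separate losing the hydroxy group from gaining the ethyl group; a plain hydrogen, a methyl group or a methoxy group at this position could help to tell these apart. Going by these compounds, whether a longer chain such as propyl, or an amine, would give a similarly low number also remains open.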